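Removing a Methoxy Group: Compound 3 to Compound 4

The source may report more compounds than this note shows. Statements on the series, on what has been measured and on what is new or still open speak of the compounds shown alone.

Of the compounds shown here, three have been measured in an ADME assay on L1210/0 cells (Mus musculus) for cytotoxicity, with a stated time of 48 h; a lower number here means a stronger inhibitor, a higher number a weaker inhibitor. Compound 1 `COc1ccc(-c2ncnc3c2ncn3C[C@@H]2C[C@H](CO)c3ccccc32)cc1` gives 17600 nM. Compound 2 `OC[C@H]1C[C@@H](Cn2cnc3c(-c4ccccc4)ncnc32)c2ccccc21` gives 28100 nM in this assay. The two share one core and differ only by hydrogen in place of methoxy on an aromatic carbon, a change that produced a 1.6-fold higher number from compound 1 to compound 2 (0.20 log units; within the scatter), so the two numbers cannot be told apart with confidence.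

Compound 3 `COc1ccc(C(=O)/C=C/c2cc(=O)[nH]c(=O)n2COCCO)cc1` is built on a different core; the difference between the two cores is not broken down here. In this assay compound 3 gives 33500 nM, which stands close to the values of compound 1 and compound 2.

Compound 4 `O=C(/C=C/c1cc(=O)[nH]c(=O)n1COCCO)c1ccccc1` has not yet been measured. It differs from compound 3 by hydrogen in place of methoxy on an aromatic carbon, the same change already seen between compound 1 and compound 2, made at a place described in the same words.

Because that earlier change gave only a 1.6-fold higher number from compound 1 to compound 2 (0.20 log units; within the scatter), a step of similar size is expected here, namely a 1.3-fold higher number from compound 3 to compound 4 (0.13 log units; within the scatter). Compound 4 is therefore expected to give 45000 nM in this assay. The estimated range for compound 4 runs from 20000 nM to 100000 nM.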

Compound 4, half-maximal inhibitory concentration: 43300 nM
The estimate for compound 4 lay 1.0-fold (0.02 log units) above the measured number; the range from low to high includes it.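

Replacing 4-methoxyphenyl with phenyl on the core of compound 3 gives, in this assay, a 1.3-fold higher number from compound 3 to compound 4 (0.11 log units; within the scatter). Set side by side, the two steps agree: the same change on two cores in this assay, a 1.6-fold higher number (0.20 log units; within the scatter) from compound 1 to compound 2 and a 1.3-fold higher number (0.11 log units; within the scatter) from compound 3 to compound 4, 1.2-fold (0.09 log units) apart, within the scatter of two such steps. So, in this assay, the change carries from one core to the other with no difference that can be told from scatter, but neither step can be separated from scatter on its own, which means the pair does not show that the methoxy group affects the number at all, and two cores cannot speak for every core in the series.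

The compounds shown hold only methoxy or hydrogen at this place on the ring, which leaves open how an amine, a carboxylic acid or a longer chain such as ethoxy would read there. They also leave open whether a methoxy group at another place on the same ring would give a step of similar size.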